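Swapping a phenyl for a pyrazole on the amide

This account rests on a few compounds, and the source may have more. Where it says the series, first, only, none or still open, it means among the compounds named here.

Within the data shown here, the three compounds measured so far share one core, and each carries an amide at its edge. Compound 1 `CCC(=O)N1CCc2cc(CNC(=O)c3ccccc3)ccc21` gives 87% in an assay on HEK293 cells for inhibition of Indoleamine 2,3-dioxygenase 1 (Homo sapiens), tested at 10 uM; on this read-out higher numbers stand for more inhibition at the one concentration tested (going by the name of the read-out) and lower numbers for less inhibition. Compound 2 `CC(C)CC(=O)N1CCc2cc(CNC(=O)c3ccco3)ccc21` gives 100% in this assay, and compound 3 `CCC(=O)NCc1ccc2c(c1)CCN2C(=O)c1ccccc1` gives 41% in this assay. Compound 1 thus stands second highest of the three: compound 2 lies above it by a margin beyond the scatter, and compound 3 lies far below it.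

Compound 4 `CCC(=O)N1CCc2cc(CNC(=O)c3ccnn3C)ccc21` is compound 1 with one change: 1-methyl-1H-pyrazol-5-yl in place of phenyl on a carbonyl carbon. Among the measured compounds shown here, no pair of measured compounds differs in exactly this way, so the size of the step has to be judged from what the set shows. Compound 2, which also carries a five-membered aromatic ring with a hetero atom on the carbonyl carbon, gives 100%, so such a ring at this place goes with a high number in this assay. Compound 4 is therefore expected to keep a high number, with an estimated 80% in this assay, plausibly between 55% and 98%. Compound 4 is expected to show a step of a number 7 percentage points lower from compound 1 to compound 4 (within the scatter), a change not beyond the scatter and, if anything, toward slightly less inhibition.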

Compound 4, a percentage reported as inhibition, at one concentration (the size of the read-out at that concentration, not a potency): 14%
For compound 4 the middle estimate is 66 percentage points above the measured one, outside the stated range (below it).
By their numbers in this assay, from the lowest: compound 4; then compound 3; then compound 1; then compound 2.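

The step of a number 73 percentage points lower from compound 1 to compound 4 (beyond the scatter) in this assay, a large one, shows that the aromatic ring on this carbonyl carbon matters greatly: with the rest of compound 1 left unchanged, replacing this one group takes away most of the inhibition seen at the single concentration tested. The size of the group cannot be the whole story as measured by heavy atoms, since phenyl and 1-methyl-1H-pyrazol-5-yl have the same count, and neither carries a net charge; they differ in ring size, in ring nitrogens, in the methyl group and in having 0 versus 2 hydrogen-bond acceptors. Nothing available explains the drop or singles out one of these differences as responsible.

The compounds shown leave open which of these differences counts, since no compound separates the ring nitrogens from the methyl group or the five-membered ring from the six-membered one. A pyridyl ring, a thienyl ring or a 1H-pyrazol-5-yl group without the methyl, each on the core and propanoyl amide of compound 1, would pull these apart.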